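The compounds below may be only part of what the source reports. "The series", "measured", "known", "first", "only" and "open" are said of these compounds alone.

Measured compounds in an ADME assay on Huh-7 cells (Homo sapiens) for cytotoxicity; a higher number here means that more compound is tolerated, a lower number that less compound is tolerated:

Compound 1 `Cc1ccccc1-c1nn(-c2ccc(F)cc2)cc1CNCCN1CCN(C)CC1`: in this assay compound 1 gives only a limit, > 20000 nM.
Compound 2 `CSc1ccc(-n2cc(CNCCN3CCN(C)CC3)c(-c3ccccc3C)n2)cc1`: in this assay compound 2 gives 17000 nM.
Compound 3 `Cc1ccccc1-c1nn(-c2cccc(C(F)(F)F)c2)cc1CNCCN1CCN(C)CC1`: in this assay compound 3 gives 18000 nM.

Compound 3 and compound 2 sit within the scatter of each other, with a 1.1-fold higher number from compound 2 to compound 3 (0.02 log units; within the scatter). The step of an at least 1.1-fold lower number from compound 1 to compound 3 (0.04 log units; that floor lies within the scatter) likewise stays within the scatter, as does an at least 1.1-fold lower number from compound 1 to compound 2 (0.07 log units; that floor lies within the scatter); one value, that of compound 1, is a limit (the limit of > 20000 nM in this assay, at which 1 of the 3 values shown sits).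

Compound 4 `Cc1ccccc1-c1nn(-c2ccc(N)cc2)cc1CNCCN1CCN(C)CC1` carries the change (4-aminophenyl in place of 3-(trifluoromethyl)phenyl on an aromatic nitrogen). All three measured steps are swaps of the aryl group on the same aromatic nitrogen, and none of them moved this assay beyond the scatter. No step beyond the scatter is therefore expected for compound 4 either, with an expected no change at the digits printed from compound 3 to compound 4 (within the scatter). Compound 4 is estimated at 18000 nM, in the range 9000 nM to 36000 nM.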

Compound 4, half-maximal cytotoxic concentration: > 20000 nM
Compound 4: no number, only a limit (the forecaster's own chance of this, stated with the estimate: 30%); middle value at least 1.1-fold (0.04 log units) away from the limit.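

In this assay compound 4, the only one shown whose aryl group on the aromatic nitrogen carries a hydrogen-bond donor, gives only a limit, not a number: the limit of > 20000 nM in this assay, at which 2 of the 4 values shown sit.
The readable steps, an at least 1.1-fold higher number from compound 3 to compound 4 (0.04 log units; that floor lies within the scatter) and an at least 1.1-fold higher number from compound 2 to compound 4 (0.07 log units; that floor lies within the scatter), give floors only, so the 4-aminophenyl group brings no lower number at this position. The step between the two limits cannot be read.

Still open, from the compounds shown here alone, is whether a carboxylic acid or a longer basic amine chain on this aryl group would move this assay beyond the scatter.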